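Phenyl Gives Way to tert-Butyl After Compound 3

The source may hold more compounds than are shown below. What is called first, only, known or untested is meant among the compounds shown, and "the series" means these compounds.

Among the compounds with values here, in a functional assay on MDA-MB-231 cells (Homo sapiens) for inhibition, read by sulforhodamine B assay, with a stated time of 48 h (a lower number here means a stronger inhibitor of growth, a higher number a weaker inhibitor of growth), compound 3 `c1ccc(-c2nc3ncccn3c2CN2CCCCC2)cc1` gives 30 nM as the lowest of the three numbers measured so far. In this assay compound 2 `c1ccc(-c2nc3ncccn3c2CN2CCCC2)cc1` stands nearest with 70 nM on the scale, and compound 1 `Oc1ccc(-c2nc3ncccn3c2CN2CCCCC2)cc1` stands furthest with 7230 nM on the scale.

Compound 4 `CC(C)(C)c1nc2ncccn2c1CN1CCCCC1` has not yet been measured. It differs from compound 3 by tert-butyl in place of phenyl on an aromatic carbon of the shared core.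

Two measured steps offer guidance, though neither removes the phenyl. Hydrogen in place of hydroxy on an aromatic carbon of the phenyl gave a 240-fold lower number from compound 1 to compound 3 (2.38 log units; beyond the scatter) as a large change, which shows that the number can move far with a single substitution on that group. Piperidin-1-yl in place of pyrrolidin-1-yl gave a 2.3-fold lower number from compound 2 to compound 3 (0.37 log units; beyond the scatter) as a modest change, and it concerns a different part of the molecule.

Within the data shown here, no measured compound lacks the phenyl, so the direction rests on judgement and the range must stay wide. A large move to a weaker number is expected, estimated as a 27-fold higher number from compound 3 to compound 4 (1.43 log units; beyond the scatter) in this assay for now. The expected value for compound 4 is 800 nM with an estimated range from 100 nM to 6000 nM in this estimate.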

Compound 4, concentration for 50% growth inhibition: 1490 nM
Estimate against measurement, compound 4: 1.9-fold (0.27 log units) below, and the stated range covers the measured number.
By their numbers in this assay, from the lowest: compound 3; then compound 2; then compound 4; then compound 1.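

The earlier compounds shown here varied only a hydroxy on the phenyl and the saturated ring of the amine, whereas compound 4 removes the phenyl from this aromatic carbon altogether, and in this assay this gives a 50-fold higher number from compound 3 to compound 4 (1.70 log units; beyond the scatter) for a swap of one carbon-only group for another. The number at this position therefore answers to the whole group and not only to a substituent on it, and 4-hydroxyphenyl proves the poorest of the three groups seen there, since tert-butyl in its place gives a 4.9-fold lower number from compound 1 to compound 4 (0.69 log units; beyond the scatter) while staying well short of phenyl, so the order at this carbon runs phenyl, tert-butyl, 4-hydroxyphenyl. Nothing in the available data accounts for this order.

The compounds shown leave open whether the low number needs an aromatic ring at this carbon, as a cyclohexyl or a pyridine ring there would test, or merely a group of similar size. They also leave open whether a methoxy or a fluorine in place of the hydroxy on the phenyl would keep the number near that of compound 3 or lose as much as compound 1 does.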